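A Single Methyl on the Small Core of Compound 3

The source may hold more compounds than are shown below. What is called first, only, known or untested is meant among the compounds shown, and "the series" means these compounds.

Of the compounds shown here, three have been measured in a functional assay on HFL1 cells (Homo sapiens) for inhibition, read by sulforhodamine B assay, with a stated time of 48 h; a lower number here means a smaller maximal response, a higher number a larger maximal response. Compound 1 `COc1ccccc1NC(=O)CSc1nnc(NC2=NC(=O)/C(=C/c3ccc(Cl)cc3)S2)s1` gives 17.4%, and compound 2 `COc1ccc(/C=C2\SC(Nc3nnc(SCC(=O)Nc4ccc(Cl)cc4)s3)=NC2=O)cc1` gives 53.8%. Compound 3 `O=C1CS/C(=N/N=C/c2cccnc2)N1`, a far smaller molecule, gives 92.1%, the highest of the three numbers; its gap to compound 2 and its gap to compound 1 both lie beyond the scatter. The unmeasured compound 4 `CC1S/C(=N/N=C/c2cccnc2)NC1=O` keeps all of compound 3 and adds one change: methyl in place of hydrogen on a saturated ring carbon.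

Within the data shown here, no two measured compounds differ in only one place, so nothing yet shows what such a small addition does. Given compound 3 at 92.1%, this change is expected to move the number little. The expected step is a number 4.1 percentage points lower from compound 3 to compound 4 (within the scatter). For compound 4 the estimate is 88%, with a range from 70% to 100%.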

Compound 4, largest response reached (Emax), in percent of the reference or control that the assay uses in the HFL1 assay: 84.6%
Estimate against measurement, compound 4: 3.4 percentage points above, within the range that was stated.
By their numbers in the HFL1 assay, from the lowest: compound 1; then compound 2; then compounds 4 and 3 (each within the scatter of the next).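

On this saturated ring carbon, the first single-place step available is a number 7.5 percentage points lower from compound 3 to compound 4 (within the scatter) in the HFL1 assay, so methyl in place of hydrogen does not shift the number beyond the usual scatter. In a physicochemical assay for inhibition, with a stated time of 3 min (a lower number here means a smaller maximal response, a higher number a larger maximal response), compound 4 gives 35.8% and compound 3 is entered as "not determined" (no result reported), so the step in that assay cannot be read. Nothing available explains the result. Open, going by these compounds, is whether an ethyl group, a longer chain or a carboxylic acid on this carbon would be met the same way.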